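Ring Size at the Chain Carbon: Expectation for Compound 4

A few compounds are considered here, and "the series" means these few. Any claim that something is new, unique, unknown or untested is made for them only; others in the source may bear on it.

Compound 1 `CCc1nc2c(-c3ccc(OC)nc3C(F)(F)F)ccnc2n1C(C)C1CCC1` gives 0.8 nM in an assay for binding affinity to Corticotropin releasing factor receptor (Rattus norvegicus); a higher number here means a weaker inhibitor, a lower number a stronger inhibitor.
Compound 2 `CCCC(C)n1c(CC)nc2c(-c3ccc(OC)nc3C)ccnc21` gives 1.1 nM.
Compound 3 `CCc1nc2c(-c3ccc(OC)nc3C)ccnc2n1C(C)C1CC1` gives 2 nM.

Compound 3 carries the highest number of the three, but its gap to compound 2 lies within the scatter; only compound 1 stands beyond it. Compound 4 `CCc1nc2c(-c3ccc(OC)nc3C)ccnc2n1C(C)C1CCC1` differs from compound 3 by cyclobutyl in place of cyclopropyl on a saturated chain carbon bound to an aromatic nitrogen and a saturated chain carbon. Among the measured compounds shown here, one measured step touches this position: a 1.8-fold higher number from compound 2 to compound 3 (0.26 log units; within the scatter), a change too small to count. Compound 1 also carries a cyclobutyl group, yet it differs from compound 3 at a second place as well, so its value alone cannot separate the two changes. A step no larger than the scatter is therefore expected, in either direction. The estimate for compound 4 is 1.4 nM, between 0.6 nM and 3.2 nM. The expected step is a 1.4-fold lower number from compound 3 to compound 4 (0.15 log units; within the scatter).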

Compound 4, inhibition constant: 2.1 nM
Estimate against measurement, compound 4: 1.5-fold (0.18 log units) below; the range from low to high includes it.
By their numbers in this assay, from the lowest: compounds 1, 2, 3 and 4 (each within the scatter of the next, the first and the last beyond it).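

In this assay, cyclobutyl and cyclopropyl on this saturated chain carbon cannot be told apart, with a 1.1-fold higher number from compound 3 to compound 4 (0.02 log units; within the scatter). Cyclobutyl and propyl at the same place also cannot be separated, with a 1.9-fold higher number from compound 2 to compound 4 (0.28 log units; within the scatter), so ring size and ring versus open chain make no readable difference among these three groups. Among the compounds shown here, the one step beyond the scatter belongs to another place, the aromatic carbon where methyl stands in place of trifluoromethyl, and it is modest: a 2.6-fold higher number from compound 1 to compound 4 (0.42 log units; beyond the scatter). No measurement at hand gives a reason for these steps. As far as these compounds go, whether an amine or a longer chain at the chain carbon would keep the number this low remains open.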